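The source may report more compounds than this note shows. Statements on the series, on what has been measured and on what is new or still open speak of the compounds shown alone.

In an ADME assay on cells (Splenocyte, Mus musculus, strain BALB/c) for cytotoxicity, read by MTT assay, tested at 1 ug/mL (on this read-out lower numbers stand for a weaker effect and higher numbers for a stronger effect at the one concentration tested), compound 1 `CCCCCCCCCCCCCCC(N)COCc1ccccc1` gives 0%. Going by the values given here, for compound 2 `CCCCCCCCCCCCCCC(COCc1ccccc1)NC(=O)CCCC(=O)OC` the result in this assay is "not determined" (no result reported), so compound 2 stands at no single number on this scale, and no measured step leads from it to anything else. Compound 3 `CCCCCCCCCCCCCCC(COCc1ccccc1)N(CC)CC` differs from compound 2 by a group of 5 heavy atoms (4 carbon, 1 nitrogen; no ring) in place of a group of 10 heavy atoms (6 carbon, 1 nitrogen, 3 oxygen; no ring), on a saturated chain carbon bound to two saturated chain carbons. With nothing measured along this step, the writer expects no change beyond the usual scatter in this assay, anchored only by the low level of compound 1 at 0%. Compound 3 is therefore expected to give 5% in this assay, between 0% and 30%.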

Compound 3, a percentage reported as activity, at one concentration (the size of the read-out at that concentration, not a potency): 14.1%
Beside the measured number, compound 3's estimate is 9.1 percentage points below it; the measured number falls inside the stated range.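

In this assay, the position on a saturated chain carbon bound to two saturated chain carbons proves able to shift the read-out: diethylamino in place of amino gives a number 14.1 percentage points higher from compound 1 to compound 3 (beyond the scatter). The step from compound 2 to compound 3 cannot be read, as compound 2 has no result. Nothing available explains the step from amino to diethylamino.

The compounds shown leave open whether dimethylamino or a piperidine ring at this place would give a similar read-out. They also leave open whether a longer chain on the nitrogen would change it further.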